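The compounds below may be only part of what the source reports. "The series", "measured", "known", "first", "only" and "open" are said of these compounds alone.

Measured so far:
- Compound 1 `COc1ccc(/C(Cl)=C/C=C(\C#N)C(=O)c2c(C)[nH]c3ccccc23)cc1`: in a functional assay on MCF7 cells (Homo sapiens) for cytotoxicity, read by sulforhodamine B assay, with a stated time of 48 h (on this read-out lower numbers stand for higher toxicity in this test and higher numbers for lower toxicity in this test), compound 1 gives > 100000 nM, which is a limit of the assay and not a number.
- Compound 2 `COc1ccc(/C(Cl)=C/C=C(\C#N)C(=O)c2c[nH]c3ccc(Br)cc23)cc1`: in this assay compound 2 gives > 100000 nM, likewise a limit of the assay.

Within the data shown here, compound 1 stands at the limit of > 100000 nM in this assay, at which 2 of the 2 values shown sit, so no measured number for it is known; the two values together show only that neither compound 1 nor compound 2 reached half-kill within the tested range. Among the measured compounds shown here, no step between measured compounds is available from these data.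

Compound 3 `COc1ccc(/C(Cl)=C/C=C(\C#N)C(=O)c2c(C)[nH]c3ccccc23)cc1OC` differs from compound 1 by methoxy in place of hydrogen on an aromatic carbon, a methoxy in place of hydrogen on an aromatic carbon. For the measured compounds named here, with both measured values sitting at the limit, there is no measured step that would point in either direction for this change. In this assay the step that the limit leaves unreadable from compound 1 to compound 3 is therefore expected to be none beyond the scatter, with compound 3 most likely again reported only as a limit. Compound 3 is estimated at 150000 nM, with a range from 30000 nM to 1000000 nM.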

Compound 3, concentration lethal to 50% of the cells: > 100000 nM
Compound 3: no number, only a limit; the forecaster's own chance of this, stated with the estimate: 80%; the middle value is on the limit's open side.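

No step can be read from compound 1 to compound 3, because both results are limits of the assay and not numbers: the limit of > 100000 nM in this assay, at which 3 of the 3 values shown sit.

The compounds shown leave open whether compound 1, compound 2 and compound 3 differ at all in toxicity to these cells, and which change to the shared core, if any, would give a measured number.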